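Aryl versus alkyl on the triazole carbon in this series

A few compounds are considered here, and "the series" means these few. Any claim that something is new, unique, unknown or untested is made for them only; others in the source may bear on it.

Compound 3 `CCCCc1cn(C[C@H](O)[C@H]2OC(=O)C(OCc3ccccc3)=C2OCc2ccccc2)nn1` gives 18100 nM in a functional assay on HeLa cells (Homo sapiens) for antiproliferative activity, read by MTT assay, with a stated time of 72 h; on this read-out lower numbers stand for stronger inhibition and higher numbers for weaker inhibition. Among the three numbers measured so far it stands second highest: compound 2 `O=C1O[C@H]([C@@H](O)Cn2cc(-c3cc(C(F)(F)F)cc(C(F)(F)F)c3)nn2)C(OCc2ccccc2)=C1OCc1ccccc1` gives 35500 nM, within the scatter of compound 3, while compound 1 `O=C1O[C@H]([C@@H](O)Cn2cc(-c3ccc(Br)cc3)nn2)C(OCc2ccccc2)=C1OCc1ccccc1` gives 3910 nM, beyond the scatter on the lower side. For the measured compounds named here, the single step measured so far that touches the same position is a 4.6-fold higher number from compound 1 to compound 3 (0.67 log units; beyond the scatter), a modest loss when the aryl group was replaced by the chain. Compound 4 `COc1ccc(-c2cn(C[C@H](O)[C@H]3OC(=O)C(OCc4ccccc4)=C3OCc3ccccc3)nn2)cc1` carries 4-methoxyphenyl in place of butyl on an aromatic carbon. This change puts an aromatic ring back where compound 1 has one, though not the same ring; compound 2 shows that an aryl group at this position does not by itself secure the lower number of compound 1. Because a 4.6-fold higher number from compound 1 to compound 3 (0.67 log units; beyond the scatter) went against the chain, a partial reversal is expected, and compound 4 is estimated at 6500 nM (range 2500 nM to 16000 nM), a step of a 2.8-fold lower number from compound 3 to compound 4 (0.44 log units; beyond the scatter) that is expected to be modest.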

Compound 4, half-maximal inhibitory concentration: 16400 nM
For compound 4 the middle estimate is 2.5-fold (0.40 log units) below the measured one; measured number outside the range, above it.
By their numbers in this assay, from the lowest: compound 1; then compounds 4, 3 and 2 (each within the scatter of the next, the first and the last beyond it).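

In this assay, a 1.1-fold lower number from compound 3 to compound 4 (0.04 log units; within the scatter) puts the 4-methoxyphenyl group level with the butyl chain, so at this carbon of the triazole an aromatic ring alone does not separate a compound from the chain. The substituent on that ring does separate them: with the ring kept, methoxy in place of bromo gives a 4.2-fold higher number from compound 1 to compound 4 (0.62 log units; beyond the scatter), a modest step, and among these one-place comparisons only the bromo compound stands apart.

As far as these compounds go, it remains open whether bromo is specifically required, or whether a plain phenyl, a chloro or an amine in its place would hold the number of compound 1. A longer chain in place of butyl is likewise untested among the compounds shown. No measurement at hand explains either step.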